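This account rests on a few compounds, and the source may have more. Where it says the series, first, only, none or still open, it means among the compounds named here.

Going by the values given here, compound 3 `CCCCCC12CCC(c3nnc(-c4ccccc4C(F)(F)F)n3C)(CC1)CC2` is the only member of this set with a number in an assay on CHO-K1 cells for inhibition of 11-beta-hydroxysteroid dehydrogenase type 2 (Homo sapiens), read by scintillation proximity assay; a higher number here means a weaker inhibitor, a lower number a stronger inhibitor: compound 3 gives 1300 nM. Compound 1 `CCSCCC12CCC(c3nnc(-c4ccccc4C(F)(F)F)n3C)(CC1)CC2` reaches only a limit of the assay, > 4000 nM. Compound 2 `CCS(=O)(=O)CCCCC12CCC(c3nnc(-c4ccccc4C(F)(F)F)n3C)(CC1)CC2` likewise reaches only a limit, > 4000 nM. Both sit at the limit of > 4000 nM in this assay, at which 2 of the 3 values shown sit.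

Compound 4 `CCOCC12CCC(c3nnc(-c4ccccc4C(F)(F)F)n3C)(CC1)CC2` differs from compound 3 by ethoxy in place of butyl on a saturated chain carbon bound to a saturated ring carbon. Among the compounds with values here, no measured step matches this change, but two come near it. The step of an at least 3.0-fold lower number from compound 1 to compound 3 (0.48 log units; beyond the scatter) removed a sulfur from the chain and improved the number; the step of an at least 3.0-fold lower number from compound 2 to compound 3 (0.48 log units; beyond the scatter) removed a sulfonyl and did the same. The step that the two limits leave unreadable from compound 1 to compound 2 is not readable. Both readable steps run from a chain bearing a heteroatom toward a plain hydrocarbon chain, and the change to compound 4 runs the other way, from butyl to ethoxy. Compound 4 is therefore expected to show a weaker number in this assay, by about a 2.7-fold higher number from compound 3 to compound 4 (0.43 log units; beyond the scatter), and may well reach only the limit. Compound 4 is estimated at 3500 nM, within 1500 nM to 8000 nM.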

Compound 4, half-maximal inhibitory concentration: > 4000 nM
Compound 4 gave a limit, no number; the forecaster's own chance of this, stated with the estimate: 50%; middle value at least 1.1-fold (0.05 log units) from the limit.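

In this assay, ethoxy in place of butyl on a saturated chain carbon bound to a saturated ring carbon gives an at least 3.0-fold higher number from compound 3 to compound 4 (0.48 log units; beyond the scatter), so an oxygen in this chain goes the same way as the sulfur of compound 1 and the sulfonyl of compound 2. Among the compounds shown, only compound 3, with its plain hydrocarbon chain, gives a number, while the three chains carrying a heteroatom all end at the same limit: the limit of > 4000 nM in this assay, at which 3 of the 4 values shown sit. The steps to compound 4 from compound 1 and from compound 2 cannot be read, since both ends of each are limits.

The step also swaps butyl for a shorter chain, so the oxygen and the chain length cannot be told apart. From the compounds shown here alone, whether a longer plain chain such as hexyl, or an amine or a carboxylic acid at this place, would move the number remains open.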